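The source may report more compounds than this note shows. Statements on the series, on what has been measured and on what is new or still open speak of the compounds shown alone.

The measured compounds, each with its value in a functional assay on HCT-15 cells (Homo sapiens) for cytotoxicity, read by CCK-8 assay and cell counting, with a stated time of 72 h; on this read-out lower numbers stand for stronger inhibition and higher numbers for weaker inhibition:

Compound 1, `COc1ccc(-c2cc3ccccc3c(-c3cccc(N)c3)n2)cc1`: 2350 nM
Compound 2, `COc1ccc(-c2cc3ccccc3c(-c3ccc(O)cc3)n2)cc1`: a limit of the assay, > 50000 nM
Compound 3, `COc1ccc(-c2cc3cc(C)ccc3c(-c3cccc(N)c3)n2)cc1OC`: 2700 nM

Compound 4, `COc1ccc(-c2cc3cc(C)ccc3c(-c3ccc(O)cc3)n2)cc1OC`, has not been measured in this assay. One change links compound 1 to compound 2: 4-hydroxyphenyl in place of 3-aminophenyl on an aromatic carbon. In this assay this gave an at least 21-fold higher number from compound 1 to compound 2 (1.32 log units; beyond the scatter), and its size is only a bound because of the limit of > 50000 nM in this assay, at which 1 of the 3 values shown sits. How the core of compound 3 differs from the core of compound 1 is not broken down here; their two values in this assay sit within the scatter of each other. From compound 3 to compound 4 the same kind of change is made, (4-hydroxyphenyl in place of 3-aminophenyl on an aromatic carbon); the surroundings differ only in wording, the place being meta to a 4-methoxyphenyl group in the first pair and meta to a large group in the second. Compound 4 is therefore expected to give a step of a 22-fold higher number from compound 3 to compound 4 (1.35 log units; beyond the scatter), resting on the earlier step of an at least 21-fold higher number from compound 1 to compound 2 (1.32 log units; beyond the scatter) from a starting value like that of compound 3, 2700 nM. For compound 4 the estimate in this assay is 60000 nM, between 20000 nM and 200000 nM.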

Compound 4, half-maximal inhibitory concentration: 2520 nM
Estimate against measurement, compound 4: 24-fold (1.38 log units) above; the measured number lies below the stated range.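

In this assay, 4-hydroxyphenyl in place of 3-aminophenyl on the core of compound 3 gave a 1.1-fold lower number from compound 3 to compound 4 (0.03 log units; within the scatter), so the change did not carry over from the core of compound 1 with the same outcome: the same change on two cores in this assay, an at least 21-fold higher number (1.32 log units; beyond the scatter) from compound 1 to compound 2 and a 1.1-fold lower number (0.03 log units; within the scatter) from compound 3 to compound 4, at least 22-fold (1.35 log units) apart, beyond the scatter of two such steps. Compound 2 sits at a limit of the assay, so the earlier step is a bound and not an exact size: the limit of > 50000 nM in this assay, at which 1 of the 4 values shown sits. The result does not show which part of the difference between the two cores goes with this gap, and two pairs give no rule for other cores.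

The compounds shown leave open which of the two outcomes is the more usual one on further cores, including a core that carries only the added methyl or only the added methoxy. Also open, on these data alone, is how a 3-hydroxyphenyl or a 4-aminophenyl group would behave on these cores, since each would separate the choice of atom from its place on the ring.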